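A second methyl on a weak ornithine decarboxylase inhibitor

This account rests on a few compounds, and the source may have more. Where it says the series, first, only, none or still open, it means among the compounds named here.

Compound 1, `CC(CN)C(CN)C(=O)O`: in an assay for inhibition of Ornithine decarboxylase (Rattus norvegicus) (on this read-out higher numbers stand for weaker inhibition and lower numbers for stronger inhibition), compound 1 gives 720000 nM.
Compound 2, `CC(C)(CN)C(CN)C(=O)O`: compound 2 reaches only the limit of this assay, > 11000000 nM.
Compound 3, `CC(CN)(CCN)C(=O)O`: compound 3 likewise reaches only the limit of this assay, > 11000000 nM.

Compound 3 therefore stands at the limit of > 11000000 nM in this assay, at which 2 of the 3 values shown sit, so its inhibition constant is known only as a limit and not as a number. Compound 4, `CC(CN)C(C)(CN)C(=O)O`, differs from compound 3 by methyl in place of hydrogen on a saturated chain carbon bound to two saturated chain carbons. For the measured compounds named here, the only measured step that concerns a methyl entering the shared core is an at least 15-fold higher number from compound 1 to compound 2 (1.18 log units; beyond the scatter), although that methyl sat on a saturated chain carbon bound to three saturated chain carbons rather than two. Nothing among the measurements points to a further methyl bringing the number down. Compound 3 already sits at the limit of this assay, and compound 4 is expected to remain at or beyond it. The expected step is a step that the limit leaves unreadable from compound 3 to compound 4. Compound 4 is thus estimated at 20000000 nM, with a range from 5000000 nM to 80000000 nM.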

Compound 4, inhibition constant: 1650000 nM
Compound 4: middle estimate off by 12-fold (1.08 log units), on the high side, outside the stated range (below it).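

In this assay, methyl in place of hydrogen on a saturated chain carbon bound to two saturated chain carbons gives an at least 6.6-fold lower number from compound 3 to compound 4 (0.82 log units; beyond the scatter) and so brings a measurable number out of a limit. Compared with compound 1, compound 4 shows a 2.3-fold higher number from compound 1 to compound 4 (0.36 log units; beyond the scatter) as the result of methyl in place of hydrogen on a saturated chain carbon bound to a carbonyl carbon and two saturated chain carbons, so a methyl on the shared core need not push the number to the limit. The exchange of hydrogen for methyl has no single direction across these cores: the same change on two cores in this assay, an at least 15-fold higher number (1.18 log units; beyond the scatter) from compound 1 to compound 2 and an at least 6.6-fold lower number (0.82 log units; beyond the scatter) from compound 3 to compound 4, at least 100-fold (2.00 log units) apart, beyond the scatter of two such steps.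

On these data alone, whether an ethyl or a longer chain at this position would keep the number measurable stays open, as does the effect of replacing an amine or the carboxylic acid on compound 4. As far as these compounds go, the full size of the steps to and from the limit values also stays open: the limit of > 11000000 nM in this assay, at which 2 of the 4 values shown sit.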